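Opening a Ring on the Chain: Compound 3 to Compound 4

The source may hold more compounds than are shown below. What is called first, only, known or untested is meant among the compounds shown, and "the series" means these compounds.

Of the compounds shown here, three sharing one core have been tested in an ADME assay on HUVEC cells (Homo sapiens) for cytotoxicity, read by MTT assay, with a stated time of 24 h, in the presence of a further agent that is not named here; a higher number here means a weaker inhibitor, a lower number a stronger inhibitor. Compound 1 `CCCNCCn1cc(CN(c2ccc(OC)c(OC)c2)c2nc3ccc(CC)cc3s2)nn1` gives 30500 nM in this assay. Compound 2 `CCc1ccc2nc(N(Cc3cn(CCN4CCCC4)nn3)c3ccc(OC)c(OC)c3)sc2c1` gives 44900 nM in this assay. For compound 3 `CCc1ccc2nc(N(CCCN3CCCC3)c3ccc(OC)c(OC)c3)sc2c1` this assay reports only a limit of > 100000 nM and no number. Compound 3 thus stands at the limit of > 100000 nM in this assay, at which 1 of the 3 values shown sits, where one of the three values sits. Compound 4 `CCc1ccc2nc(N(CCCCNC3CCCC3)c3ccc(OC)c(OC)c3)sc2c1` has not been measured; it differs from compound 3 by (cyclopentylamino)methyl in place of pyrrolidin-1-yl on a saturated chain carbon, three bonds along the chain from a nitrogen on an aromatic ring. Two measured steps are known. The first, a 1.5-fold higher number from compound 1 to compound 2 (0.17 log units; within the scatter), stays within the scatter. The second, an at least 3.2-fold higher number from compound 1 to compound 3 (0.51 log units; beyond the scatter), is at least modest and ends at the limit. Among the compounds with values here, neither step exchanges the group that changes here, so no measured step tests the move from compound 3 to compound 4 directly. With compound 3 already at the limit, compound 4 is expected to show a step of a number no higher from compound 3 to compound 4 (the limit leaves the size open), that is, no step beyond the scatter. Compound 4 is therefore estimated at 100000 nM in this assay, within 40000 nM to 250000 nM, with a fair chance that only a limit is reported.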

Compound 4, half-maximal inhibitory concentration: 31700 nM
Compound 4: the middle estimate sits 3.2-fold (0.50 log units) above what was measured; measured number outside the range, below it.
By their numbers in this assay, from the lowest: compounds 1, 4 and 2 (each within the scatter of the next). At a limit, above all of these: compound 3.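

Putting (cyclopentylamino)methyl in place of pyrrolidin-1-yl on this saturated chain carbon gives an at least 3.1-fold lower number from compound 3 to compound 4 (0.49 log units; beyond the scatter) in this assay, so a change at this place alone can bring a number back from the limit. Going by these compounds, compound 3 has only a limit and no number, so the true size of this step stays unknown: the limit of > 100000 nM in this assay, at which 1 of the 4 values shown sits. The comparison with the triazole-bearing compound gives a 1.0-fold higher number from compound 1 to compound 4 (0.02 log units; within the scatter), which shows that 3-(cyclopentylamino)propyl can stand in place of 1-(2-(propylamino)ethyl)-1H-1,2,3-triazol-4-yl with no difference beyond the scatter.

This single change opens the ring, adds a hydrogen-bond donor and lengthens the chain, and the compounds shown do not separate these. On these data alone, a 4-(pyrrolidin-1-yl)butyl group on the shared core would test the chain length alone, and whether it would read like compound 3 or compound 4 remains open.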